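The source may hold more compounds than are shown below. What is called first, only, known or untested is meant among the compounds shown, and "the series" means these compounds.

Compound 1 `Fc1cccc(F)c1C#Cc1ccc2nccc(Cl)c2c1`: 89.7%
Compound 2 `Fc1cccc(F)c1C#Cc1cnc2ccccc2c1`: 90.4%

In a functional assay on LS174T cells (Homo sapiens) for inhibition, with a stated time of 4 days, tested at 10 uM (on this read-out lower numbers stand for a weaker effect and higher numbers for a stronger effect at the one concentration tested), compound 1 gives 89.7%, and compound 2 gives 90.4%; the two numbers lie within the scatter of each other, so compound 1 sits alongside compound 2 rather than apart from it. Compound 3 `Fc1cccc(F)c1C#Cc1ccc2ncccc2c1` is not yet measured. It differs from compound 1 in one place: hydrogen in place of chloro on an aromatic carbon. For the measured compounds named here, no measured pair shows what this change does here, so the step in this assay is expected to be small, perhaps slightly downward, and possibly none beyond the scatter. For compound 3 the expected result is 80% (range 55% to 95%), which means an expected step of a number 9.7 percentage points lower from compound 1 to compound 3 (within the scatter).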

Compound 3, a percentage reported as inhibition, at one concentration (the size of the read-out at that concentration, not a potency): 80.1%
Beside the measured number, compound 3's estimate is 0.1 percentage points below it, within the range that was stated.
By their numbers in this assay, from the lowest: compounds 3, 1 and 2 (each within the scatter of the next, the first and the last beyond it).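

For the compounds shown here, replacing the chloro group opposite the ring nitrogen with hydrogen gives the first direct reading of this position: in this assay the result is a number 9.6 percentage points lower from compound 1 to compound 3 (within the scatter). The chloro group is therefore not shown to be needed for the effect at the one concentration tested. No measurement here offers an explanation for this result.

Going by these compounds, whether an amine, a methoxy group or a carboxylic acid at this position would leave the read-out equally undisturbed remains open. A single-concentration read-out also leaves any difference in potency between these compounds unresolved.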